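Hydroxamate series: aryl replacement on the triazole of compound 3

This account rests on a few compounds, and the source may have more. Where it says the series, first, only, none or still open, it means among the compounds named here.

Compound 3 `Cn1c(Sc2ccc(C(=O)NO)cc2)nnc1-c1cccs1` is one of three compounds with a number in an assay on Sf9 cells for inhibition of protein deacetylase HDAC6 (Homo sapiens), read by fluorescence; on this read-out lower numbers stand for stronger inhibition and higher numbers for weaker inhibition. Compound 3 gives 8 nM in this assay. Its nearest neighbour is compound 2 `O=C(NO)c1ccc(Cc2noc(-c3ccccc3)n2)cc1`, which gives 6 nM in this assay; the two lie within the scatter of each other. Its furthest neighbour is compound 1 `Cc1cc(-c2nnc(Sc3ccc(C(=O)NO)c(F)c3)n2C)nn1C`, which gives 2240 nM in this assay, a gap well beyond the scatter.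

Compound 4 `Cc1cc(-c2nnc(Sc3ccc(C(=O)NO)cc3)n2C)nn1C` has not been measured. It differs from compound 3 in one place: 1,5-dimethyl-1H-pyrazol-3-yl in place of thiophen-2-yl on an aromatic carbon. Among the compounds with values here, compound 1 also carries the 1,5-dimethyl-1H-pyrazol-3-yl group on the same core, though compound 1 is not a single-change neighbour of compound 4, so no exact step can be drawn from it. Within the data shown here, still, the only compound bearing this group, compound 1, sits far up the scale at 2240 nM, which points to a large step toward weaker inhibition for compound 4.

The expected step from compound 3 to compound 4 is therefore a 130-fold higher number from compound 3 to compound 4 (2.10 log units; beyond the scatter), a clear rise beyond the scatter. Compound 4 is estimated at 1000 nM, with a likely range from 300 nM to 4000 nM, pending measurement.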

Compound 4, half-maximal inhibitory concentration: 5 nM
Compound 4: middle estimate off by 200-fold (2.30 log units), on the high side; the measured number lies below the stated range.
By their numbers in this assay, from the lowest: compounds 4, 2 and 3 (each within the scatter of the next); then compound 1.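

In this assay, the aromatic carbon between two ring nitrogen atoms accepts 1,5-dimethyl-1H-pyrazol-3-yl in place of thiophen-2-yl with a 1.6-fold lower number from compound 3 to compound 4 (0.20 log units; within the scatter), so this exchange of one five-membered aromatic ring for another, with its two added methyl groups, does not move the read-out beyond the scatter. Within the data shown here, the weak value of compound 1 therefore cannot be assigned to the 1,5-dimethyl-1H-pyrazol-3-yl group alone: the single change of hydrogen in place of fluoro on an aromatic carbon gives a 450-fold lower number from compound 1 to compound 4 (2.65 log units; beyond the scatter), and this one pair is the whole basis for that large step. Nothing measured here accounts for either step.

Open, going by these compounds, is whether a fluoro group at the same place on the thiophen-2-yl compound brings a step of similar size, or whether the large step appears only alongside 1,5-dimethyl-1H-pyrazol-3-yl. Also open, on these data alone, is how far the position on the five-membered aromatic ring with 3 nitrogen extends beyond these two rings, for example to a carboxylic acid, an amine or a longer chain, and whether chloro or methoxy in place of fluoro behaves as fluoro does.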